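Working notes: bromo in place of methyl on compound 2

This account rests on a few compounds, and the source may have more. Where it says the series, first, only, none or still open, it means among the compounds named here.

Values in a functional assay on MDA-MB-231 cells (Homo sapiens) for inhibition, read by sulforhodamine B assay (on this read-out higher numbers stand for weaker inhibition of growth and lower numbers for stronger inhibition of growth), for the compounds tested so far:
- compound 1 `COc1ccccc1CN1CCC=C(CCC(=O)NO)C1=O` gives (> 10000 nM), a limit of the assay
- compound 2 `Cc1ccc(CN2CCC=C(CCC(=O)NO)C2=O)cc1` gives (1430 nM), a number
- compound 3 `O=C(CCC1=CCCN(Cc2ccc3ccccc3c2)C1=O)NO` gives ("not determined" (no result reported)), no result

Among the compounds with values here, compound 2 holds the only actual number in this small set (1430 nM). The entry for compound 1 is a limit and not a number (> 10000 nM). Compound 3 has no reported result ("not determined" (no result reported)), so there is no second number to compare with compound 2.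

Compound 4 `O=C(CCC1=CCCN(Cc2ccc(Br)cc2)C1=O)NO` has not yet been measured. It carries bromo in place of methyl on an aromatic carbon, para to a large group, with 4-methylphenyl becoming 4-bromophenyl. Within the data shown here, no measured pair in the set isolates a single change, so the series offers no direct guide to the size of this step.

In this assay no step beyond the scatter is expected, and no firm direction can be assigned. The expectation is anchored on compound 2 (1430 nM), and the range is kept wide since this is a single number. The estimated change is small (a 1.1-fold lower number from compound 2 to compound 4 (0.04 log units; within the scatter)) and is expected to stay within the scatter. The expected value for compound 4 is 1300 nM in this assay (estimated range 450 nM to 4000 nM) pending measurement.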

Compound 4, concentration for 50% growth inhibition: 1630 nM
Compound 4: middle estimate off by 1.3-fold (0.10 log units), on the low side, within the range that was stated.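

In this assay, the change from 4-methylphenyl to 4-bromophenyl gives the series its first readable step: a 1.1-fold higher number from compound 2 to compound 4 (0.06 log units; within the scatter). On this read-out, methyl and bromo on an aromatic carbon, para to a large group, cannot be told apart, and compound 4 joins compound 2 as a second number, so this pair offers a comparison that the earlier entries could not. Compound 1 remains a limit and not a number, the only one among the values shown: the limit of > 10000 nM in this assay, at which 1 of the 4 values shown sits.

The compounds shown hold only methyl and bromo at this place, so it remains open whether a very different group there, such as an amine or a carboxylic acid, would also leave the value within the scatter. No step can be read from compound 1 or compound 3 to any other compound, so how this assay responds to a change in the aromatic group itself, as opposed to this single replacement, also stays unresolved.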